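Moving a piperidine one carbon farther along the chain

A few compounds are considered here, and "the series" means these few. Any claim that something is new, unique, unknown or untested is made for them only; others in the source may bear on it.

Compound 1 `CCCc1ccc2c(c1)sc(=O)n2CCN1CCCCC1`: 0.6 nM
Compound 2 `CCCc1ccc2c(c1)sc(=O)n2CCN1CCCCCC1`: 0.56 nM

Going by the values given here, in an assay on membranes from brain for displacement of a labelled ligand from Sigma non-opioid intracellular receptor 1 (Cavia porcellus) (on this read-out higher numbers stand for weaker inhibition and lower numbers for stronger inhibition), compound 2 sits with compound 1 within the scatter; the only measured step, a 1.1-fold lower number from compound 1 to compound 2 (0.03 log units; within the scatter), changed nothing beyond it. Compound 3 `CCCc1ccc2c(c1)sc(=O)n2CCCN1CCCCC1` differs from compound 2 by (piperidin-1-yl)methyl in place of azepan-1-yl on a saturated chain carbon, two bonds along the chain from an aromatic nitrogen. Among the compounds with values here, no measured step covers a longer chain to the ring nitrogen, so the one step at hand, which was flat, gives no reason to expect a change beyond the scatter: compound 3 is estimated at 0.8 nM (range 0.3 nM to 3 nM), meaning an expected step of a 1.4-fold higher number from compound 2 to compound 3 (0.15 log units; within the scatter).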

Compound 3, inhibition constant: 1.2 nM
Beside the measured number, compound 3's estimate is 1.5-fold (0.18 log units) below it, within the range that was stated.
By their numbers in this assay, from the lowest: compounds 2, 1 and 3 (each within the scatter of the next, the first and the last beyond it).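

In this assay, going by these compounds alone, (piperidin-1-yl)methyl in place of azepan-1-yl gives a 2.1-fold higher number from compound 2 to compound 3 (0.33 log units; beyond the scatter) and is the first step at this position to pass the scatter, though only modestly. (piperidin-1-yl)methyl in place of piperidin-1-yl gives a 2.0-fold higher number from compound 1 to compound 3 (0.30 log units; within the scatter) and so does not pass it, which means the new group separates from only one of the two earlier compounds. Nothing at hand explains why the two steps fall on either side of the scatter.

The compounds shown leave open how azepan-1-yl would fare on the same chain as compound 3. They also leave open whether a morpholine ring or a still longer chain would move the number further.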